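Swapping cyclopropyl for pentan-3-yl on an EP3 antagonist scaffold

The source may hold more compounds than are shown below. What is called first, only, known or untested is meant among the compounds shown, and "the series" means these compounds.

Of the compounds shown here, three built on the same core have been tested in a functional assay on CHO cells for antagonist activity at prostaglandin E2 receptor EP3 subtype (Homo sapiens), read by cAMP accumulation, with a stated time of 30 min; a higher number here means a weaker inhibitor, a lower number a stronger inhibitor. Compound 1 `CC(C)[C@@H](C[C@H]1SC(=O)NC1=O)c1ccc(-c2ccc3cccc(F)c3c2)[nH]c1=O` gives 17 nM. Compound 2 `CC(C)/C(=C1\C(=O)NC(=O)N1C)c1ccc(-c2ccc3cccc(F)c3c2)[nH]c1=O` gives 350 nM. Compound 3 `O=C1NC(=O)/C(=C/C(c2ccc(-c3ccc4cccc(F)c4c3)[nH]c2=O)C2CC2)O1` gives 33 nM. Among these three numbers compound 3 holds the second highest place: its nearest neighbour is compound 1, whose number is lower but within the usual scatter, so the two cannot be told apart; its furthest neighbour is compound 2, whose number is higher by a margin beyond the scatter.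

The next compound, compound 4 `CCC(CC)C(/C=C1\OC(=O)NC1=O)c1ccc(-c2ccc3cccc(F)c3c2)[nH]c1=O`, has not been measured. It differs from compound 3 in one place: pentan-3-yl in place of cyclopropyl on a saturated chain carbon bound to an aromatic carbon and a double-bonded chain carbon. Among the compounds with values here, no measured pair shows this exact change, so its effect can only be guessed from the spread seen so far. Because compound 1 sits at 17 nM and compound 3 at 33 nM, the two carrying different groups at that same place yet lying within the scatter of each other, the step from a 1.5-fold higher number from compound 3 to compound 4 (0.18 log units; within the scatter) is expected to be small, if anything a modest weakening. Compound 4 is therefore estimated at 50 nM, with a likely range from 15 nM to 170 nM in this assay .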

Compound 4, half-maximal inhibitory concentration: 23 nM
Beside the measured number, compound 4's estimate is 2.2-fold (0.34 log units) above it; the range from low to high includes it.
By their numbers in this assay, from the lowest: compounds 1, 4 and 3 (each within the scatter of the next); then compound 2.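

Within the data shown here, this is the first direct look at this place, a saturated chain carbon bound to an aromatic carbon and a double-bonded chain carbon: in this assay, pentan-3-yl in place of cyclopropyl gives a 1.4-fold lower number from compound 3 to compound 4 (0.16 log units; within the scatter). The two compounds therefore cannot be told apart, even though an open group of five carbons has replaced a three-membered ring of carbon only, so for this one pair, neither ring nor size of group shows up in the read-out. Nothing available here explains why the number holds.

Only these two groups, both made of carbon alone, can be compared directly at this place. As far as these compounds go, what an amine or a carboxylic acid would do there remains open, as does whether a much longer chain would still fit this result.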